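The compounds below may be only part of what the source reports. "The series", "measured", "known", "first", "only" and "open" are said of these compounds alone.

Measured in a functional assay on HepG2 cells (Mus musculus) for antiproliferative activity against HepG2 (Homo sapiens), read by MTT assay, with a stated time of 48 h; a lower number here means a stronger inhibitor, a higher number a weaker inhibitor:
- Compound 1 `COc1cc(/C=C/c2nnc(NC(=O)c3ccc(Br)cc3)s2)c(Br)c(OC)c1OC`: 200 nM
- Compound 2 `COc1cc(/C=C/c2nnc(NC(=O)c3cccc(Cl)c3)s2)c(Br)c(OC)c1OC`: 150 nM
- Compound 3 `COc1cc(/C=C/c2nnc(NC(=O)c3ccc(Cl)cc3)s2)c(Br)c(OC)c1OC`: 180 nM

Compound 3 cannot be separated from the other two on these numbers. The data show a 1.1-fold lower number from compound 1 to compound 3 (0.05 log units; within the scatter) and a 1.2-fold higher number from compound 2 to compound 3 (0.08 log units; within the scatter).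

Compound 4 `COc1cc(/C=C/c2nnc(NC(=O)c3cccc(F)c3)s2)c(Br)c(OC)c1OC` is the next compound to be considered. It differs from compound 3 as follows: 3-fluorophenyl in place of 4-chlorophenyl on a carbonyl carbon. In short, it has 3-fluorophenyl in place of 4-chlorophenyl on a carbonyl carbon.

Among the measured compounds shown here, no fluorine-bearing compound has been measured, so the evidence is indirect. The measured steps that bear on this change are a 1.2-fold higher number from compound 2 to compound 3 (0.08 log units; within the scatter), which exchanges the same two chlorophenyl groups, and a 1.3-fold lower number from compound 1 to compound 2 (0.12 log units; within the scatter), which ends on a 3-chlorophenyl group. Both are small. No step beyond the scatter is therefore expected in this assay, and no direction can be favoured. The expected result is a 1.1-fold lower number from compound 3 to compound 4 (0.02 log units; within the scatter).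

Compound 4 is estimated at 170 nM, with an expected range of 85 nM to 350 nM.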

Compound 4, half-maximal inhibitory concentration: 170 nM
Compound 4: middle estimate and measured number agree at the digits printed; measured number inside the range.
By their numbers in this assay, from the lowest: compounds 2, 4, 3 and 1 (each within the scatter of the next).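

In this assay, a fluorine-bearing ring on this carbonyl carbon behaves like the chlorine- and bromine-bearing rings: 3-fluorophenyl in place of 4-chlorophenyl gives a 1.1-fold lower number from compound 3 to compound 4 (0.02 log units; within the scatter), and fluoro in place of chloro on an aromatic carbon gives a 1.1-fold higher number from compound 2 to compound 4 (0.05 log units; within the scatter). 3-fluorophenyl in place of 4-bromophenyl gives a 1.2-fold lower number from compound 1 to compound 4 (0.07 log units; within the scatter), so all four halogen-bearing phenyl groups now lie within the scatter of one another, and swapping one halogen for another on this ring separates none of these compounds. Nothing measured here speaks to why the number stays so flat. Every group shown at this place is a halogen-bearing phenyl ring, so it remains open whether a methoxy, a nitrile, a dimethylamino group or a carboxylic acid on that ring would produce a step beyond the scatter. Also open, as far as these compounds go, is whether an unsubstituted phenyl or a cyclohexyl group on the carbonyl carbon would do so.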